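Adding a second methyl to a pyridine amide

The source may hold more compounds than are shown below. What is called first, only, known or untested is meant among the compounds shown, and "the series" means these compounds.

Compound 1, `Cc1cccc(C(=O)Nc2nn[nH]n2)n1`, is tested in a functional assay on the whole organism for inhibition, with Rattus norvegicus as the target, at a dose of 1 mg/kg by the oral route (a lower number here means a weaker effect, a higher number a stronger effect of the compound at the dose given), where compound 1 gives 40%. Among the three measured compounds this is the second highest number. Compound 2, `Cc1cc(Cl)cc(C(=O)Nc2nn[nH]n2)n1`, gives 66% in this assay, and compound 3, `O=C(Nc1nn[nH]n1)c1ccccn1`, gives 0%. Compound 4, `Cc1ccc(C)c(C(=O)Nc2nn[nH]n2)n1`, has not been measured in this assay yet. It differs from compound 1 in one place: methyl in place of hydrogen on an aromatic carbon.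

Two measured steps speak to this change. The step of a number 26 percentage points higher from compound 1 to compound 2 (beyond the scatter) shows that placing a small group on the aromatic ring of compound 1 raised the number in this assay. The step of a number 40 percentage points lower from compound 1 to compound 3 (beyond the scatter) shows that taking away the methyl already present removed the effect entirely, so substitution on this ring is clearly felt. Both point in the same direction, and a modest rise is therefore expected from the added methyl. The expected step is a number 15 percentage points higher from compound 1 to compound 4 (beyond the scatter). Compound 4 is estimated to give 55% in this assay, within a range from 35% to 75%.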

Compound 4, a percentage reported as inhibition, in the whole organism at one dose (the size of the read-out at that dose, not a potency): 37%
For compound 4 the middle estimate is 18 percentage points above the measured one; measured number inside the range.
By their numbers in this assay, from the lowest: compound 3; then compounds 4 and 1 (each within the scatter of the next); then compound 2.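

In this assay, a methyl on the aromatic carbon ortho to a group of 8 heavy atoms and para to a methyl group gives a number 3 percentage points lower from compound 1 to compound 4 (within the scatter), so the core of compound 1 takes this added methyl with no change that can be told from the scatter. This differs from the two earlier changes on the ring, a number 26 percentage points higher from compound 1 to compound 2 (beyond the scatter) and a number 40 percentage points lower from compound 1 to compound 3 (beyond the scatter), and shows that not every change on this ring moves the number. Nothing measured here explains why this methyl leaves the number where it is.

From the compounds shown here alone, whether this position stays just as flat for a group other than methyl, such as a chloro, a longer chain, an amine or a carboxylic acid, remains open. With only a single methyl at this position, it is also unclear whether any group placed here can raise the number.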